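Aryl swap on the shared core: notes toward compound 4

The compounds below may be only part of what the source reports. "The series", "measured", "known", "first", "only" and "open" are said of these compounds alone.

Measured so far in an ADME assay on microsomes from liver (Rattus norvegicus) for metabolic stability, read by LC-MS, using NADPH, at 37 degrees C; a higher number here means that the compound lasts longer, a lower number that the compound disappears faster:
compound 1 `Cc1ccc(C)c(-c2nc(CN3CCC(C(=O)NCCCN4C[C@H](C)C[C@H](C)C4)CC3)c(C)o2)c1` — 0.5 h
compound 2 `Cc1ccccc1-c1nc(CN2CCC(C(=O)NCCCN3CCCC(CC(C)C)C3)CC2)c(C)o1` — 0.0383 h
compound 3 `Cc1ccccc1-c1nc(CN2CCC(C(=O)NCCCCN3C[C@H](C)C[C@H](C)C3)CC2)c(C)o1` — 0.2 h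

Compound 1 gives the highest number of the three in this assay; compound 3 is nearest, compound 2 furthest, both gaps beyond the scatter. Compound 4 `COc1cccc(Br)c1-c1nc(CN2CCC(C(=O)NCCCN3C[C@H](C)C[C@H](C)C3)CC2)c(C)o1` differs from compound 1 only at the aryl group: 2-bromo-6-methoxyphenyl in place of 2,5-dimethylphenyl on an aromatic carbon. Among the measured compounds shown here, the one measured step, a 5.2-fold higher number from compound 2 to compound 3 (0.72 log units; beyond the scatter), concerns the group on the saturated chain carbon and leaves the aryl group untouched, so it does not bear on this change. For the measured compounds named here, no measured step informs the direction. The expectation is therefore no step beyond the scatter, a 1.3-fold lower number from compound 1 to compound 4 (0.10 log units; within the scatter), with a wide range. Compound 4 is estimated at 0.4 h, between 0.15 h and 1 h.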

Compound 4, half-life: 0.0583 h
Estimate against measurement, compound 4: 6.9-fold (0.84 log units) above; the measured number lies below the stated range.
By their numbers in this assay, from the lowest: compounds 2 and 4 (each within the scatter of the next); then compound 3; then compound 1.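

In this assay the aryl group on the shared core proves to be a place that moves the number: 2-bromo-6-methoxyphenyl in place of 2,5-dimethylphenyl gives an 8.6-fold lower number from compound 1 to compound 4 (0.93 log units; beyond the scatter) on an otherwise unchanged molecule. The earlier compounds shown here offered no step at this position. Nothing measured here accounts for the size or direction of this step.

The change alters the bromine, the methoxy group and the two methyl groups together, so their separate contributions remain unresolved. A 2-methoxyphenyl or 2-bromophenyl group on the same core would separate them.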